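Lactone ring against open diol chain on a quinone tail

The source may report more compounds than this note shows. Statements on the series, on what has been measured and on what is new or still open speak of the compounds shown alone.

Measured so far:
- compound 1 `COC1=C[C@H](O)[C@H](C/C=C(\C)CC/C=C(\C)C[C@@H]2C[C@@H](C)C(=O)O2)[C@@H](C)C1=O`: > 30000 nM in a functional assay on A549 cells (Homo sapiens) for inhibition, read by sulforhodamine B assay, with a stated time of 48 h; on this read-out higher numbers stand for weaker inhibition of growth and lower numbers for stronger inhibition of growth
- compound 2 `COC1=C[C@H](O)[C@H](C/C=C(\C)CC/C=C(\C)C[C@H](O)/C=C(\C)CO)[C@@H](C)C1=O`: > 30000 nM in this assay
- compound 3 `COC1=C(OC)[C@H](OC(C)=O)[C@H](C/C=C(\C)CC/C=C(\C)C[C@H](O)/C=C(\C)CO)[C@@H](C)C1=O`: 29000 nM in this assay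

In this assay compound 2 gives only a limit of the assay, > 30000 nM, and no number. Compound 1 likewise gives only a limit, > 30000 nM. The change between them is a group of 7 heavy atoms (5 carbon, 2 oxygen; one five-membered non-aromatic ring with 1 hetero atom) in place of a group of 7 heavy atoms (5 carbon, 2 oxygen; no ring), on a saturated chain carbon bound to a double-bonded chain carbon, and its step, a step that the two limits leave unreadable from compound 2 to compound 1, cannot be sized, since the limit of > 30000 nM in this assay, at which 2 of the 3 values shown sit, hides whatever difference there may be. For the measured compounds named here, compound 3 is the one compound with a true number, 29000 nM. The difference between the core of compound 3 and the core of compound 2 is not broken down here.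

Compound 4 `COC1=C(OC)[C@H](OC(C)=O)[C@H](C/C=C(\C)CC/C=C(\C)C[C@@H]2C[C@@H](C)C(=O)O2)[C@@H](C)C1=O` is not yet measured. It carries the same change as before, (a group of 7 heavy atoms (5 carbon, 2 oxygen; one five-membered non-aromatic ring with 1 hetero atom) in place of a group of 7 heavy atoms (5 carbon, 2 oxygen; no ring), on a saturated chain carbon bound to a double-bonded chain carbon), now on the core of compound 3. Because a step that the two limits leave unreadable from compound 2 to compound 1 gives no readable size, the step from compound 3 to compound 4 is expected to be small, a 1.0-fold higher number from compound 3 to compound 4 (0.01 log units; within the scatter). Compound 4 is therefore estimated at 30000 nM in this assay, between 10000 nM and 90000 nM, and may well come back only as a limit.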

Compound 4, concentration for 50% growth inhibition: 11300 nM
For compound 4 the middle estimate is 2.7-fold (0.42 log units) above the measured one, and the stated range covers the measured number.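

In this assay, the five-membered ring group in place of the open-chain group gives a 2.6-fold lower number from compound 3 to compound 4 (0.41 log units; beyond the scatter), so on this core the change goes with stronger inhibition of growth. This is a single pair, so it shows the effect of the change on one core only and does not show that the effect carries over to another core. The matching step on the other core cannot be read, because both of its compounds give only limits of the assay rather than numbers: the limit of > 30000 nM in this assay, at which 2 of the 4 values shown sit.

The compounds shown leave open whether the shift depends on the ring itself, on the loss of the hydrogen-bond donors of the open chain, or on the defined stereocentres of the ring. They also say nothing about how a lactam or a six-membered lactone would behave in place of the five-membered ring on either core.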